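Ethynyl to Prop-1-en-1-yl on the Amide Carbonyl

The source may hold more compounds than are shown below. What is called first, only, known or untested is meant among the compounds shown, and "the series" means these compounds.

Compound 1, `C#CC(=O)N(Cc1ccc(OC)c(O)c1)c1cc(OC)c(OC)c(OC)c1`, stands lowest of the two numbers measured in a functional assay on MGC-803 cells (Homo sapiens) for inhibition, read by MTT assay, with a stated time of 48 h (a lower number here means a stronger inhibitor, a higher number a weaker inhibitor), where compound 1 gives 170 nM. Compound 2, `COc1ccc(N(Cc2cc(OC)c(OC)c(OC)c2)C(=O)CCl)cc1O`, gives 24500 nM in this assay, a gap from compound 1 that lies well beyond the scatter. Compound 3, `C/C=C/C(=O)N(Cc1ccc(OC)c(O)c1)c1cc(OC)c(OC)c(OC)c1`, differs from compound 1 by prop-1-en-1-yl in place of ethynyl on a carbonyl carbon. Within the data shown here, no step between measured compounds covers such a change, so the expectation rests on the change alone: compound 3 is expected to come out weaker, with a step of a 4.7-fold higher number from compound 1 to compound 3 (0.67 log units; beyond the scatter) expected in this assay. Compound 3 is estimated at 800 nM, within a range of 250 nM to 3000 nM.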

Compound 3, half-maximal inhibitory concentration: 27 nM
Beside the measured number, compound 3's estimate is 30-fold (1.47 log units) above it, outside the stated range (below it).
By their numbers in this assay, from the lowest: compound 3; then compound 1; then compound 2.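

In this assay, prop-1-en-1-yl in place of ethynyl on a carbonyl carbon gives a 6.3-fold lower number from compound 1 to compound 3 (0.80 log units; beyond the scatter). The ethynyl triple bond is therefore not needed for a low number at this position, and the double bond of prop-1-en-1-yl does better in this pair. Nothing available explains this step. On these data alone, it remains open whether the step follows the double bond or the longer chain, which an ethenyl or a prop-1-yn-1-yl group on this carbonyl would separate. As far as these compounds go, how a still longer chain or a dimethylamino-bearing butenyl group would read is also open.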